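Does a chloro group shift cytotoxicity in compound 4?

The compounds below may be only part of what the source reports. "The series", "measured", "known", "first", "only" and "open" are said of these compounds alone.

- Compound 1 `CN(CCCn1c(=O)oc2ccc(Cl)cc21)Cc1ccccc1`: > 100000 nM, a limit of the assay
- Compound 2 `CN(CCCn1c(=O)sc2ccccc21)Cc1ccccc1`: 10000 nM
- Compound 3 `CN(CCCn1c(=O)sc2cc(Br)ccc21)Cc1ccccc1`: 13200 nM

In an ADME assay on SH-SY5Y cells (Homo sapiens) for cytotoxicity, read by MTT assay, with a stated time of 72 h (a higher number here means a weaker inhibitor, a lower number a stronger inhibitor), only two of these results are true numbers. Compound 2 gives 10000 nM, and this lies within the scatter of compound 3 at 13200 nM.

Compound 4 `CN(CCCn1c(=O)sc2ccc(Cl)cc21)Cc1ccccc1` has not been measured yet. It differs from compound 2 by chloro in place of hydrogen on an aromatic carbon.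

Going by the values given here, the one measured step that bears on this change is a 1.3-fold higher number from compound 2 to compound 3 (0.12 log units; within the scatter), where bromo takes the place of hydrogen on an aromatic carbon. That is a single step with a different group, so it is only a rough guide. Among the compounds with values here, compound 1 also carries a chloro group, but the core of compound 1 differs and its result is only a limit, so it gives no step to use here.

No change beyond the scatter is therefore expected in this assay. The expected change is a 1.2-fold higher number from compound 2 to compound 4 (0.08 log units; within the scatter). The estimate for compound 4 is 12000 nM, with an expected range from 6000 nM to 30000 nM.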

Compound 4, half-maximal inhibitory concentration: 9900 nM
For compound 4 the middle estimate is 1.2-fold (0.08 log units) above the measured one; measured number inside the range.
By their numbers in this assay, from the lowest: compounds 4, 2 and 3 (each within the scatter of the next). At a limit, above all of these: compound 1.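

In this assay, placing chloro on this aromatic carbon, meta to a fused ring and para to a fused ring, gives a 1.0-fold lower number from compound 2 to compound 4 (0.00 log units; within the scatter). Going by these compounds alone, this is the first direct reading of chloro on the shared core; until now the only step on that core was the bromo one, a 1.3-fold higher number from compound 2 to compound 3 (0.12 log units; within the scatter), so two different halogens at two sites now both leave the value within the scatter of the unsubstituted compound 2. Nothing at hand gives a reason for this result.

Compound 1 carries chloro on a different core and gives > 100000 nM, a limit of the assay, so the effect of that core change cannot be read. Still open, from the compounds shown here alone, is whether an amine or a carboxylic acid on this same aromatic carbon, or a longer chain leading to the nitrogen, would also stay within the scatter.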